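Adding a Methyl Group to a Weak Growth Inhibitor

The compounds below may be only part of what the source reports. "The series", "measured", "known", "first", "only" and "open" are said of these compounds alone.

Measured in a functional assay on PC-3 cells (Homo sapiens) for antiproliferative activity, read by MTT assay, with a stated time of 96 h; a lower number here means a stronger inhibitor of growth, a higher number a weaker inhibitor of growth:
- compound 1 `c1ccc(Nc2ccc3ccccc3n2)nc1` gives > 30000 nM, which is a limit of the assay and not a number.
- compound 2 `Cc1ccnc(Nc2ccc3ccccc3n2)c1` gives 26700 nM.
- compound 3 `COc1ccc(Cl)c2ccc(Nc3ccccn3)nc12` gives 29200 nM.

Compound 1 and compound 2 differ by one change, (methyl in place of hydrogen on an aromatic carbon). The step that goes with it, an at least 1.1-fold lower number from compound 1 to compound 2 (0.05 log units; that floor lies within the scatter), is only a floor because compound 1 sits at the limit of > 30000 nM in this assay, at which 1 of the 3 values shown sits, so the true size of the step is not known. Compound 3 and compound 1 share the same pattern of a two-ring core joined to a one-ring partner through an amine, but the difference between the two cores is not broken down here. Compound 3 and compound 2 give numbers that lie within the usual scatter of each other.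

Compound 4 `COc1ccc(Cl)c2ccc(Nc3cc(C)ccn3)nc12` has not been measured. It relates to compound 3 as compound 2 relates to compound 1: the change is methyl in place of hydrogen on an aromatic carbon, and the place is the same word for word, so it is the same change. From compound 3 to compound 4 a step of a 1.5-fold lower number from compound 3 to compound 4 (0.16 log units; within the scatter) is expected, resting on compound 1 and compound 2 and the step of an at least 1.1-fold lower number from compound 1 to compound 2 (0.05 log units; that floor lies within the scatter), which is a floor that lies within the scatter. For compound 4 a value of about 20000 nM in this assay is expected, most likely between 8000 nM and 45000 nM.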

Compound 4, concentration for 50% growth inhibition: > 30000 nM
Compound 4 ended at the assay's limit; the forecaster's own chance of this, stated with the estimate: 30%; middle value at least 1.5-fold (0.17 log units) away from the limit.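

In this assay compound 4 gives > 30000 nM, which is a limit of the assay and not a number, and it is the second such result in this small set: the limit of > 30000 nM in this assay, at which 2 of the 4 values shown sit.

On these data alone, replacing pyridin-2-yl with 4-methylpyridin-2-yl on the core of compound 3 gives an at least 1.0-fold higher number from compound 3 to compound 4 (0.01 log units; that floor lies within the scatter), and this is only a floor, so the true size of the step stays unknown. The result therefore neither shows that the methyl change carries over from one core to the other nor shows that it fails to, and a reading at a limit cannot settle the matter: the same change on two cores in this assay, an at least 1.1-fold lower number (0.05 log units; that floor lies within the scatter) from compound 1 to compound 2 and an at least 1.0-fold higher number (0.01 log units; that floor lies within the scatter) from compound 3 to compound 4; the limit leaves it open whether they differ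

The compounds shown leave open whether methyl on this carbon, opposite the ring nitrogen, changes growth inhibition at all on either core, as every value shown lies at or close to the same limit. They also leave open whether another group at that place, such as an amine, a carboxylic acid or a longer chain, would give numbers clear of the limit on both cores, which is what a real comparison between the two cores would need.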